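The compounds below may be only part of what the source reports. "The series", "measured", "known", "first", "only" and "open" are said of these compounds alone.

In a functional assay on A549 cells (Homo sapiens) for antiproliferative activity, read by MTT assay, with a stated time of 48 h (a higher number here means a weaker inhibitor, a lower number a stronger inhibitor), compound 1 `COc1ccc(/C=C/C(=O)Nc2nnc(-c3ccc(C)cc3)s2)cc1` gives 0.66 ug/mL and compound 2 `Cc1ccc(/C=C/C(=O)Nc2nnc(-c3ccc(C)cc3)s2)cc1` gives 1.08 ug/mL, so compound 2 stands within the scatter of compound 1. Compound 3 `Cc1ccc(/C=C/C(=O)Nc2nnc(-c3ccccc3)s2)cc1` follows from compound 2 by hydrogen in place of methyl on an aromatic carbon, or 4-methylphenyl to phenyl. Among the measured compounds shown here, only one measured step is available, a 1.6-fold higher number from compound 1 to compound 2 (0.21 log units; within the scatter), and it concerns a different place in the molecule, so it bears only indirectly. No step beyond the scatter is therefore expected in this assay. The expected step is a 1.1-fold higher number from compound 2 to compound 3 (0.05 log units; within the scatter). For compound 3 the estimated value is 1.2 ug/mL, with an expected range of 0.5 ug/mL to 3 ug/mL.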

Compound 3, half-maximal inhibitory concentration: 1.58 ug/mL
Estimate against measurement, compound 3: 1.3-fold (0.12 log units) below; the measured number falls inside the stated range.
By their numbers in this assay, from the lowest: compounds 1, 2 and 3 (each within the scatter of the next, the first and the last beyond it).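

In this assay the change from 4-methylphenyl to phenyl gives a 1.5-fold higher number from compound 2 to compound 3 (0.17 log units; within the scatter) and so shows that this methyl can be lost without a step beyond the scatter. Among the compounds shown here, this is the first reading at this position, since the earlier pair differed at another place in the molecule. No available evidence accounts for the size of this step.

Going by these compounds, whether an amine or a carboxylic acid at this position would give a step beyond the scatter remains open. So does whether the same change behaves alike with the methoxy of compound 1 in place.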